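From hex-5-yn-1-yl to but-3-en-1-yl on oxygen

The source may hold more compounds than are shown below. What is called first, only, known or untested is meant among the compounds shown, and "the series" means these compounds.

Compound 1 `C=CCCCCOc1ccccc1-c1cnc(OCCC=C)n1C` gives 19000 nM
Compound 2 `C#CCCCCOc1ncc(-c2ccccc2OC)n1C` gives 21000 nM

These two values come from a functional assay on PC-3 cells (Homo sapiens) for inhibition, read by colorimetric assay and MTT assay, with a stated time of 72 h; a higher number here means a weaker inhibitor, a lower number a stronger inhibitor. Compound 2 stands at 21000 nM, level with compound 1 within the usual scatter, so the pair sets no order of potency.

The next compound to be tested is compound 3 `C=CCCOc1ncc(-c2ccccc2OC)n1C`. It carries vinyl in place of but-3-yn-1-yl on a saturated chain carbon, two bonds along the chain from an oxygen on an aromatic ring. Cut one bond further out, the same difference reads (hex-5-yn-1-yl)oxy to (but-3-en-1-yl)oxy.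

Going by the values given here, no measured pair shows this change alone, so its size cannot be read directly from the data. Compound 1 also has a but-3-en-1-yl chain on oxygen and gives 19000 nM, but it differs from compound 2 in more than this one place. A modest move toward a weaker number is therefore expected in this assay, possibly staying within the scatter. The expected change is a 1.2-fold higher number from compound 2 to compound 3 (0.09 log units; within the scatter). For compound 3 the estimated value is 26000 nM, with an expected range from 11000 nM to 60000 nM.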

Compound 3, half-maximal inhibitory concentration: 25000 nM
Compound 3: the middle estimate sits 1.0-fold (0.02 log units) above what was measured; measured number inside the range.
By their numbers in this assay, from the lowest: compounds 1, 2 and 3 (each within the scatter of the next).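

In this assay, the change from (hex-5-yn-1-yl)oxy to (but-3-en-1-yl)oxy now has a direct reading, a 1.2-fold higher number from compound 2 to compound 3 (0.08 log units; within the scatter), so vinyl in place of but-3-yn-1-yl at this position on the chain does not measurably alter the result. A second single change, hydrogen in place of pent-4-en-1-yl on a saturated chain carbon bound to an oxygen on an aromatic ring, gives a 1.3-fold higher number from compound 1 to compound 3 (0.12 log units; within the scatter), and it too does not separate the two compounds. Neither an alkyne nor an alkene on these chains therefore stands apart from the other in the three compounds shown, and no measurement here offers an explanation for this result.

Because all three values lie within the scatter of one another, these compounds do not show that anything at this position can change the number in this assay. As far as these compounds go, it remains open whether an amine, a carboxylic acid or a much longer chain in place of but-3-yn-1-yl on that saturated chain carbon would give a value beyond the scatter.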